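Methoxyphenyl in Place of a Halogenated Aryl Group

This account rests on a few compounds, and the source may have more. Where it says the series, first, only, none or still open, it means among the compounds named here.

Within the data shown here, compound 3 `Cn1ccc2c(Oc3ccc(NC(=O)c4cn(-c5ccc(F)c(Cl)c5)c5ccccc5c4=O)cc3F)ccnc21` stands second highest of the three numbers so far in a functional assay on A549 cells (Homo sapiens) for inhibition, read by MTT assay, with a stated time of 72 h (a higher number here means a weaker inhibitor, a lower number a stronger inhibitor), giving 1210 nM. Its nearest neighbour is compound 2 `Cn1ccc2c(Oc3ccc(NC(=O)c4cn(-c5ccc(Br)cc5)c5ccccc5c4=O)cc3F)ccnc21`, which gives 1390 nM; the difference, a 1.1-fold lower number from compound 2 to compound 3 (0.06 log units; within the scatter), lies within the scatter. Furthest away is compound 1 `Cn1ccc2c(Oc3ccc(NC(=O)c4cn(-c5ccc(Cl)cc5)c5ccccc5c4=O)cc3F)ccnc21`, which gives 250 nM; the step of a 4.8-fold higher number from compound 1 to compound 3 (0.68 log units; beyond the scatter) is beyond the scatter, as is a 5.6-fold higher number from compound 1 to compound 2 (0.75 log units; beyond the scatter).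

Compound 4 `COc1ccc(-n2cc(C(=O)Nc3ccc(Oc4ccnc5c4ccn5C)c(F)c3)c(=O)c3ccccc32)cc1` is the next step from compound 3: 4-methoxyphenyl in place of 3-chloro-4-fluorophenyl on an aromatic nitrogen. Among the measured compounds shown here, no measured pair swaps a halogenated aryl group for one carrying a methoxy group, so the only guidance comes from the exchanges already seen on that aromatic nitrogen. Two of them, a 4.8-fold higher number from compound 1 to compound 3 (0.68 log units; beyond the scatter) and a 5.6-fold higher number from compound 1 to compound 2 (0.75 log units; beyond the scatter), were modest steps that moved the number beyond the scatter, while the third, a 1.1-fold lower number from compound 2 to compound 3 (0.06 log units; within the scatter), did not. For the measured compounds named here, with no closer precedent, compound 4 is expected to land within the span the three measured compounds occupy. The step of a 1.7-fold lower number from compound 3 to compound 4 (0.24 log units; within the scatter) is therefore expected to be a modest lowering of the number, with a real chance that it stays within the scatter. Compound 4 is estimated at 700 nM, with a range from 150 nM to 3000 nM.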

Compound 4, half-maximal inhibitory concentration: 3210 nM
The estimate for compound 4 lay 4.6-fold (0.66 log units) below the measured number; measured number above the stated range.
By their numbers in this assay, from the lowest: compound 1; then compounds 3 and 2 (each within the scatter of the next); then compound 4.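

On the aromatic nitrogen, 4-methoxyphenyl is the only aryl group shown without a halogen, and in this assay it gives the weakest inhibitor of the four, with every comparison beyond the scatter: the exchange for 3-chloro-4-fluorophenyl (a 2.7-fold higher number from compound 3 to compound 4 (0.42 log units; beyond the scatter)), methoxy in place of bromo (a 2.3-fold higher number from compound 2 to compound 4 (0.36 log units; beyond the scatter)), and methoxy in place of chloro (a 13-fold higher number from compound 1 to compound 4 (1.11 log units; beyond the scatter)). The groups exchanged between compound 3 and compound 4 have the same count of heavy atoms, so the number at this position can change beyond the scatter without any change in that count, and the entering group differs in carrying one hydrogen-bond acceptor where the leaving group has none. Nothing measured here accounts for this rise in the number.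

The compounds shown leave open whether the rise goes with the methoxy group itself or with the absence of a halogen, a question that an unsubstituted phenyl or a 4-methylphenyl would bear on. On these data alone, it also remains open where a 4-aminophenyl, a 4-hydroxyphenyl or a longer ethoxy chain would fall relative to compound 1 and compound 4.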